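The source may report more compounds than this note shows. Statements on the series, on what has been measured and on what is new or still open speak of the compounds shown alone.

Compound 3, with the structure `Cc1cc(NCc2ccccn2)n2ncc(C3=CCOCC3)c2n1`, gives the higher of the two plain numbers seen so far in a physicochemical assay for solubility, read by HPLC, using the shake flask method, measured as kinetic solubility, with a stated time of 2 h, at pH 7.4 (on this read-out lower numbers stand for lower solubility and higher numbers for higher solubility), yet compound 2, with the structure `Cc1cc(NCc2ccccn2)n2ncc(-c3ccncc3)c2n1`, sits close beside it: compound 3 gives 171000 nM, and compound 2 gives 161000 nM, a gap of a 1.1-fold higher number from compound 2 to compound 3 (0.03 log units; within the scatter). Compound 1, with the structure `Cc1cc(NCc2ccccn2)n2ncc(-c3c(C)cccc3C)c2n1`, reaches only a limit of the assay, < 5000 nM. The next step leads to compound 4, with the structure `Cc1cc(NCc2ccccn2)n2ncc(-c3cccc(N(C)C)c3)c2n1`, in which (a group of 9 heavy atoms (8 carbon, 1 nitrogen; one six-membered aromatic ring of carbon only) in place of a group of 6 heavy atoms (5 carbon, 1 oxygen; one six-membered non-aromatic ring with 1 hetero atom), on an aromatic carbon). Within the data shown here, two measured steps bear on it. Moving from an all-carbon aromatic ring to the six-membered non-aromatic ring gave an at least 34-fold higher number from compound 1 to compound 3 (1.53 log units; beyond the scatter), and moving from that same aromatic ring to pyridin-4-yl gave an at least 32-fold higher number from compound 1 to compound 2 (1.50 log units; beyond the scatter). Compound 4 returns to an all-carbon aromatic ring, though now carrying a dimethylamino group, so a step downward in this assay is expected, of size a 5.7-fold lower number from compound 3 to compound 4 (0.76 log units; beyond the scatter). On that basis compound 4 is estimated at 30000 nM, most likely between 5000 nM and 120000 nM.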

Compound 4, solubility: 94600 nM
For compound 4 the middle estimate is 3.2-fold (0.50 log units) below the measured one, within the range that was stated.
By their numbers in this assay, from the lowest: compounds 4, 2 and 3 (each within the scatter of the next). At a limit, below all of these: compound 1.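

On an aromatic carbon of the five-membered aromatic ring, an all-carbon aromatic ring does not by itself go with a low number in this assay: 3-(dimethylamino)phenyl in place of 2,6-dimethylphenyl gives an at least 18-fold higher number from compound 1 to compound 4 (1.27 log units; beyond the scatter). Against the two six-membered rings that hold a hetero atom, 3-(dimethylamino)phenyl gives a 1.8-fold lower number from compound 3 to compound 4 (0.26 log units; within the scatter) and a 1.7-fold lower number from compound 2 to compound 4 (0.23 log units; within the scatter), so compounds 2, 3 and 4 cannot be told apart in this read-out. The value of compound 1 is a limit, not a plain number: the limit of < 5000 nM in this assay, at which 1 of the 4 values shown sits.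

The compounds shown include no unsubstituted phenyl here, so they cannot separate the part played by adding dimethylamino from the part played by removing the two methyl groups. On these data alone, how a carboxylic acid on the phenyl ring would read in this assay also stays open.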